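Configuration and Tolerance in a Salicylamide Series

A few compounds are considered here, and "the series" means these few. Any claim that something is new, unique, unknown or untested is made for them only; others in the source may bear on it.

Compound 1 `O=C(NCCCN1CCC[C@@H]2CCCC[C@@H]21)c1cc(Cl)ccc1O` gives 43 ug/mL in a functional assay on MDBK cells (Bos taurus) for cytotoxicity; a lower number here means that less compound is tolerated, a higher number that more compound is tolerated. Compound 2 `Cc1ccc(O)c(C(=O)NCCCN2[C@H](C)CC[C@@H]3CCCC[C@@H]32)c1` gives 35 ug/mL in this assay. Compound 3 `O=C(NCCCN1CCC[C@@H]2CCCC[C@H]21)c1cc(Cl)ccc1O` gives 45 ug/mL in this assay.

Compound 2 stands among three numbers that all lie within the scatter of one another: the gap to compound 1 and the gap to compound 3 are each small, so no order among the three can be read from these values. Compound 4 `Cc1ccc(O)c(C(=O)NCCCN2[C@@H]3CCCC[C@H]3CC[C@@H]2C)c1` has not yet been measured in this assay. Its relation to compound 2 is this: the two compounds have the same atoms and bonds and differ only in configuration as drawn: 2 of 3 stereo elements differ; a stereocentre at a saturated ring carbon is drawn S in compound 2 and R in compound 4; a stereocentre at a saturated ring carbon is drawn R in compound 2 and S in compound 4.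

One measured step speaks to such a change. From compound 1 to compound 3 the number moved by a 1.0-fold higher number from compound 1 to compound 3 (0.02 log units; within the scatter), and this step is informative because of the fact that compounds 1 and 3 differ only in the configuration as drawn. That single example of a configurational change left the read-out essentially unchanged. The step from compound 2 to compound 4 alters two stereocentres rather than one, so it reaches beyond what the measured pair covers, but nothing in the measured compounds points to a direction.

The expected step is therefore a 1.0-fold higher number from compound 2 to compound 4 (0.01 log units; within the scatter), that is, none beyond the scatter. Compound 4 is expected to give about 36 ug/mL, with a range from 18 ug/mL to 72 ug/mL.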

Compound 4, half-maximal cytotoxic concentration: 30 ug/mL
Beside the measured number, compound 4's estimate is 1.2-fold (0.08 log units) above it, and the stated range covers the measured number.
By their numbers in this assay, from the lowest: compounds 4, 2, 1 and 3 (each within the scatter of the next).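

In this assay, the change in configuration gave a 1.2-fold lower number from compound 2 to compound 4 (0.07 log units; within the scatter). The earlier pair had tested a difference at only one of two stereo elements, a 1.0-fold higher number from compound 1 to compound 3 (0.02 log units; within the scatter), whereas here two of three stereo elements differ at saturated ring carbons and the read-out still stays within the scatter. Across the two pairs shown, configuration as drawn therefore does not separate the compounds in this assay, and that observation now extends from a single stereocentre to two, in a compound pair with a methyl group on the aromatic ring rather than a chloro group: the fact that compounds 2 and 4 differ only in the configuration as drawn

The compounds shown leave open whether any other arrangement of the stereocentres, including a change at the third stereo element of compound 2, would move the number beyond the scatter. They also leave open whether a larger structural change would do so, such as a carboxylic acid or a methoxy group in place of the hydroxyl group, or a longer chain in the linker to the amide.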